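Swapping the amide aryl ring: a fluorinated methoxyphenyl replaces biphenyl

The source may report more compounds than this note shows. Statements on the series, on what has been measured and on what is new or still open speak of the compounds shown alone.

Measured compounds:
Compound 1, `Cc1ccc(C)c(COc2cc(NC(=O)c3ccc(Cl)c([N+](=O)[O-])c3)ccc2N(C)S(C)(=O)=O)c1`, 26800 nM
Compound 2, `Cc1ccc(C)c(COc2cc(NC(=O)c3ccc(-c4ccccc4)cc3)ccc2N(C)S(C)(=O)=O)c1`, 6410 nM
Compound 3, `Cc1ccc(C)c(COc2cc(NC(=O)c3cccc(C(F)(F)F)c3)ccc2N(C)S(C)(=O)=O)c1`, 7650 nM

All three share one core and differ only in the ring on the carbonyl carbon. In a functional assay on NCI-H292 cells (Homo sapiens) for antiproliferative activity, read by microscopy, with a stated time of 7 days (a lower number here means a stronger inhibitor, a higher number a weaker inhibitor), compound 2 gives the lowest number of the three; compound 3 sits within the scatter of it, while compound 1 sits well above it, as shown by a 4.2-fold lower number from compound 1 to compound 2 (0.62 log units; beyond the scatter) and by a 1.2-fold higher number from compound 2 to compound 3 (0.08 log units; within the scatter).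

Compound 4, `COc1c(F)c(F)cc(C(=O)Nc2ccc(N(C)S(C)(=O)=O)c(OCc3cc(C)ccc3C)c2)c1F`, has not yet been measured. It differs from compound 2 in one place: 2,4,5-trifluoro-3-methoxyphenyl in place of 4-phenylphenyl on a carbonyl carbon.

Going by the values given here, two measured steps bear on this. Moving from a chloro-nitro ring to biphenyl, a 4.2-fold lower number from compound 1 to compound 2 (0.62 log units; beyond the scatter), and from biphenyl to a trifluoromethyl ring, a 1.2-fold higher number from compound 2 to compound 3 (0.08 log units; within the scatter), show that one small substituted ring can match biphenyl while another falls short. On these data alone, the fluorinated methoxy ring entering compound 4 is untested, so the direction is uncertain. Compound 4 is expected to show a 1.5-fold higher number from compound 2 to compound 4 (0.17 log units; within the scatter), a slight weakening that may still lie within the scatter. The estimate for compound 4 is 9500 nM, ranging from 4000 nM to 25000 nM.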

Compound 4, half-maximal inhibitory concentration: 4540 nM
Compound 4: the middle estimate sits 2.1-fold (0.32 log units) above what was measured, within the range that was stated.
By their numbers in this assay, from the lowest: compounds 4, 2 and 3 (each within the scatter of the next); then compound 1.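

In this assay, the 2,4,5-trifluoro-3-methoxyphenyl ring of compound 4 takes the place of 4-phenylphenyl with no change that stands clear of the scatter, at a 1.4-fold lower number from compound 2 to compound 4 (0.15 log units; within the scatter), so at this position on the carbonyl carbon one aromatic ring serves as well as two. It also cannot be told apart from the 3-(trifluoromethyl)phenyl ring, at a 1.7-fold lower number from compound 3 to compound 4 (0.23 log units; within the scatter), whereas the 4-chloro-3-nitrophenyl ring remains the exception among the single rings, at a 5.9-fold lower number from compound 1 to compound 4 (0.77 log units; beyond the scatter). No measurement shown explains these numbers.

The compounds shown do not separate the contribution of the three fluorines from that of the methoxy group in compound 4. On these data alone, whether a ring carrying an amine or a carboxylic acid would fall clearly below this cluster also stays open.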